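The source may report more compounds than this note shows. Statements on the series, on what has been measured and on what is new or still open speak of the compounds shown alone.

Among the compounds with values here, in an ADME assay on CHO cells (Cricetulus griseus) for cytotoxicity, read by MTT assay, with a stated time of 48 h (on this read-out lower numbers stand for stronger inhibition and higher numbers for weaker inhibition), two compounds sharing one core have numbers so far. Compound 1 `Clc1ccc2c(NCCCn3c(-c4ccccc4)nc4ccccc43)ccnc2c1` gives 42000 nM. Compound 2 `FC(F)(F)c1ccc2c(c1)nc(-c1ccccc1)n2CCCNc1ccnc2cc(Cl)ccc12`, with trifluoromethyl in place of hydrogen on an aromatic carbon, gives 16200 nM, the lower of the two numbers.

Compound 3 `CS(=O)(=O)c1ccc2c(c1)nc(-c1ccccc1)n2CCCNc1ccnc2cc(Cl)ccc12` has not yet been measured. It keeps the core of compound 2 and changes one group, with methylsulfonyl in place of trifluoromethyl on an aromatic carbon.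

Within the data shown here, no measured compound carries methylsulfonyl, so there is no direct evidence for this swap. Among the measured compounds shown here, the one measured step that bears on it is a 2.6-fold lower number from compound 1 to compound 2 (0.41 log units; beyond the scatter), which is modest and took place on the same aromatic carbon. It shows that this carbon can shift the number, but only by a limited amount, and it says nothing specific about the incoming group. A small move in this assay towards a higher number is therefore expected, no larger than that earlier step. The expected change is a 1.6-fold higher number from compound 2 to compound 3 (0.21 log units; within the scatter). For compound 3 the estimated value is 26000 nM, with an expected range of 11000 nM to 60000 nM.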

Compound 3, half-maximal inhibitory concentration: 40900 nM
Beside the measured number, compound 3's estimate is 1.6-fold (0.20 log units) below it, within the range that was stated.
By their numbers in this assay, from the lowest: compound 2; then compounds 3 and 1 (each within the scatter of the next).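

In this assay, the aromatic carbon that had so far shown only the change from hydrogen to trifluoromethyl now carries a second group, and replacing trifluoromethyl with methylsulfonyl gives a 2.5-fold higher number from compound 2 to compound 3 (0.40 log units; beyond the scatter), even though neither group has a ring or a net charge. Set against hydrogen, methylsulfonyl gives a 1.0-fold lower number from compound 1 to compound 3 (0.01 log units; within the scatter), so simply placing a group on this carbon does not bring the lower number seen with trifluoromethyl; among these compounds, that number depends on which group is there. The structural differences can be counted, such as the hydrogen-bond acceptors that enter with methylsulfonyl, but no measurement here links any of them to the change in the number.

With only hydrogen, trifluoromethyl and methylsulfonyl compared on this carbon, the compounds shown cannot say whether trifluoromethyl is an isolated case or one example of a wider trend. An amine, a carboxylic acid or a methoxy group on the same carbon would show whether other groups match compound 2 or stay within the scatter of compound 1.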